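Chloro to Methyl on the Phenyl Ring of Compound 2

This account rests on a few compounds, and the source may have more. Where it says the series, first, only, none or still open, it means among the compounds named here.

Of the compounds shown here, three of the shared core have been measured in a functional assay on CHO cells for antagonist activity at adenosine receptor A2b (Homo sapiens), read by 33P incorporation, with a stated time of 20 min; a higher number here means a weaker inhibitor, a lower number a stronger inhibitor. Compound 1 `CCn1c(-c2ccccc2)nc2c(NC3CCC3)ncnc21` gives 1440 nM, compound 2 `Cn1c(-c2cccc(Cl)c2)nc2c(NC3CCCC3)ncnc21` gives 2530 nM, and compound 3 `CCn1c(-c2ccccc2)nc2c(N)ncnc21` gives 3020 nM. Compound 2 stands at the second highest of the three numbers, though its gaps to compound 3 and to compound 1 both lie within the scatter of repeated measurements, so no order among the three can be drawn from them. Among the measured compounds shown here, the one measured step, a 2.1-fold higher number from compound 1 to compound 3 (0.32 log units; beyond the scatter), is the only change in this set with a direction beyond the scatter.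

Compound 4 `Cc1cccc(-c2nc3c(NC4CCCC4)ncnc3n2C)c1` differs from compound 2 in one place: methyl in place of chloro on an aromatic carbon. The change sits on an aromatic carbon of a six-membered aromatic ring of carbon only, meta to a large group. For the measured compounds named here, no measured pair shares that change; the step from compound 1 to compound 3 concerns a nitrogen on an aromatic ring and does not bear on it. With nothing measured on this part of the molecule, compound 4 is expected to show a step of a 1.0-fold lower number from compound 2 to compound 4 (0.01 log units; within the scatter) in this assay that is none beyond the scatter. Compound 4 is therefore estimated at 2500 nM in this assay, with a range from 1000 nM to 6000 nM.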

Compound 4, inhibition constant: 6030 nM
Compound 4: middle estimate off by 2.4-fold (0.38 log units), on the low side, and the stated range ends below it.
By their numbers in this assay, from the lowest: compounds 1, 2, 3 and 4 (each within the scatter of the next, the first and the last beyond it).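

In this assay, among the compounds shown here, the exchange of 3-chlorophenyl for 3-methylphenyl gives a 2.4-fold higher number from compound 2 to compound 4 (0.38 log units; beyond the scatter) and so supplies the first measured sign that the number responds to a change on this six-membered aromatic ring, a part of the molecule that the earlier compounds did not address. Chloro and methyl each count one heavy atom and neither adds a hydrogen-bond donor or acceptor, yet of this pair the compound with chloro is the stronger inhibitor, so the two groups cannot be treated as interchangeable at this place in this series. Nothing available accounts for the step, and the data offer no explanation of it.

What the compounds shown leave open is how other groups at this place, such as fluoro, methoxy, an amine or a carboxylic acid, would compare with chloro and methyl on the same core. For the compounds shown here, they also leave open whether the same exchange would give a step of similar direction and size with the ethyl group of compound 1 on the shared core, since this single pair is the only reading of the change.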